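Cytotoxicity of Three Analogues and an Expected Fourth

This account rests on a few compounds, and the source may have more. Where it says the series, first, only, none or still open, it means among the compounds named here.

Three compounds share one core and have been measured in an ADME assay on L6 cells (Rattus norvegicus) for cytotoxicity, read by resazurin assay, with a stated time of 72 h; on this read-out lower numbers stand for an effect already at smaller amounts and higher numbers for an effect only at larger amounts of compound:

compound 1 `CCOC(=O)C1=C(C)N/C(=C/c2cc(C)n(-c3cccc(C(F)(F)F)c3)c2C)C1=O`: 100000 nM
compound 2 `CCOC(=O)C1=C(C)N/C(=C/c2cc(C)n(-c3ccc(Cl)cc3)c2C)C1=O`: 100000 nM
compound 3 `CCOC(=O)C1=C(C)N/C(=C/c2cc(C)n(-c3cccc(OC)c3)c2C)C1=O`: 56000 nM

Compound 3 has the lowest of the three numbers, but its distance to the others is small: a 1.8-fold lower number from compound 1 to compound 3 (0.25 log units; within the scatter) and a 1.8-fold lower number from compound 2 to compound 3 (0.25 log units; within the scatter) both fall within the scatter, so the three compounds cannot be ranked on this read-out.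

Compound 4 `CCOC(=O)C1=C(C)N/C(=C/c2cc(C)n(-c3ccncc3)c2C)C1=O` differs from compound 3 only in the group on the aromatic nitrogen: pyridin-4-yl in place of 3-methoxyphenyl on an aromatic nitrogen.

Two measured steps swap groups at that same position. Both stayed flat: no change at the digits printed from compound 1 to compound 2 (within the scatter) and a 1.8-fold lower number from compound 2 to compound 3 (0.25 log units; within the scatter). Three different aromatic groups at this position thus gave numbers within the scatter of one another. With no counterexample among the measured compounds, the expected step to compound 4 is a 1.4-fold higher number from compound 3 to compound 4 (0.15 log units; within the scatter), meaning no change beyond the scatter. Compound 4 is therefore estimated at 80000 nM in this assay, with a range from 30000 nM to 150000 nM.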

Compound 4, half-maximal effective concentration: 100000 nM
Compound 4: middle estimate off by 1.3-fold (0.10 log units), on the low side, and the stated range covers the measured number.
By their numbers in this assay, from the lowest: compounds 3, 1, 2 and 4 (each within the scatter of the next).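

Read in this assay the change to pyridin-4-yl gives a 1.8-fold higher number from compound 3 to compound 4 (0.25 log units; within the scatter) as well as no change at the digits printed from compound 2 to compound 4 (within the scatter) and no change at the digits printed from compound 1 to compound 4 (within the scatter) at this position. The position on the aromatic nitrogen therefore stays flat not only across aromatic rings of carbon only but also with a six-membered aromatic ring that holds a hetero atom, and the four compounds still cannot be ranked. No measurement shown here gives a reason for this flatness.

Within the data shown here, every group at this position so far is a six-membered aromatic ring, so the effect of a non-aromatic group, such as a short alkyl chain, an amine or a carboxylic acid, remains open. Going by these compounds, whether changes elsewhere on the shared core would move the number beyond the scatter also remains open.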